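The source may hold more compounds than are shown below. What is called first, only, known or untested is meant among the compounds shown, and "the series" means these compounds.

In a functional assay on A549 cells (Homo sapiens) for cytotoxicity, read by XTT assay, with a stated time of 24 h (on this read-out higher numbers stand for weaker inhibition and lower numbers for stronger inhibition), compound 1 `Cn1nnnc1SCC(=O)N/N=C/c1ccc(F)cc1` gives 3160000 nM. Among the measured compounds shown here, compound 2 `Cn1nnnc1SCC(=O)N/N=C/c1ccc(Cl)cc1` is the only other compound with the same core among those measured: in this assay compound 2 gives 100000 nM. The change between them is chloro in place of fluoro on an aromatic carbon, and it produced a 32-fold lower number from compound 1 to compound 2 (1.50 log units; beyond the scatter).

Compound 3 `Cn1nnnc1SCC(=O)N/N=C/c1cccc(F)c1` shares its atoms with compound 1 but joins them differently; how the two cores differ is not broken down here. In this assay compound 3 gives 6320000 nM, which is within the usual scatter of the value of compound 1.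

Compound 4 `Cn1nnnc1SCC(=O)N/N=C/c1cccc(Cl)c1` has not yet been measured. It differs from compound 3 by chloro in place of fluoro on an aromatic carbon. This is the same kind of change as that from compound 1 to compound 2, though not the same: in compound 2 the chloro sits para to a large group, in compound 4 meta to it. For the measured compounds named here, on the single precedent a 32-fold lower number from compound 1 to compound 2 (1.50 log units; beyond the scatter), the author expects a 21-fold lower number from compound 3 to compound 4 (1.32 log units; beyond the scatter), with the wider range reflecting that the precedent comes from the other placement. The author's estimate for compound 4 in this assay is 300000 nM, expected to lie between 100000 nM and 2000000 nM.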

Compound 4, half-maximal inhibitory concentration: 7500000 nM
For compound 4 the middle estimate is 25-fold (1.40 log units) below the measured one; measured number above the stated range.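

In this assay, chloro in place of fluoro on an aromatic carbon gave a 1.2-fold higher number from compound 3 to compound 4 (0.07 log units; within the scatter), so the change that had made a large difference on the core of compound 1 did not repeat on the core of compound 3, and the two steps disagree: the same change on two cores in this assay, a 32-fold lower number (1.50 log units; beyond the scatter) from compound 1 to compound 2 and a 1.2-fold higher number (0.07 log units; within the scatter) from compound 3 to compound 4, 38-fold (1.57 log units) apart, beyond the scatter of two such steps

This shows that, among these compounds, the size of the first step cannot be carried over to the second core, even though the two cores hold the same atoms. It does not show which difference between the cores separates the two results, and with a single step on each core it cannot say how either step would hold for other pairs in the series.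

The compounds shown carry only fluoro or chloro on the aromatic ring, which leaves open how bromo, a methoxy group or an amine there would behave in this assay. They also leave open whether a carboxylic acid on that ring would respond differently on the two cores.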